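This account rests on a few compounds, and the source may have more. Where it says the series, first, only, none or still open, it means among the compounds named here.

Measured so far in a functional assay with Cavia porcellus as the target; on this read-out lower numbers stand for stronger inhibition and higher numbers for weaker inhibition:
compound 1, `COc1ccccc1[N+](C)(C)Cc1ccccc1`, > 3000 nM
compound 2, `COc1cccc([N+](C)(C)Cc2ccccc2)c1`, > 3000 nM
compound 3, `CC(=O)Oc1ccccc1[N+](C)(C)Cc1ccccc1`, > 3000 nM

Each of these three values is a limit of this assay and not a number. For compound 1 the value > 3000 nM is a limit. For compound 2 the value > 3000 nM is likewise a limit. For compound 3 the value > 3000 nM is a limit as well. Among the measured compounds shown here, all three sit at the limit of > 3000 nM in this assay, at which 3 of the 3 values shown sit, so none of the measured pairs yields a readable comparison.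

The change from compound 1 to compound 3 is acetyl in place of methyl on an oxygen on an aromatic ring. The step it made, a step that the two limits leave unreadable from compound 1 to compound 3, cannot be sized, since both ends are limits. The cores of compound 1 and compound 2 carry the same atoms joined differently; the difference between the two cores is not broken down here.

Compound 4, `CC(=O)Oc1cccc([N+](C)(C)Cc2ccccc2)c1`, is not yet measured. It differs from compound 2 by acetyl in place of methyl on an oxygen on an aromatic ring, the same change as from compound 1 to compound 3, at a place described in the same words. With every measured value a limit, the earlier step gives no direction to carry over.

The expected step is a step that the limit leaves unreadable from compound 2 to compound 4, resting on the earlier step being unreadable and on compound 2 giving > 3000 nM in this assay. For compound 4 the expected value in this assay is 6000 nM, with a range from 3000 nM to 40000 nM, and most likely the assay will again report only a limit.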

Compound 4, half-maximal inhibitory concentration: > 3000 nM
Compound 4: a limit, no number; the forecaster's own chance of this, stated with the estimate: 85%; the middle value does not contradict the limit.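

Compound 4 gives > 3000 nM in this assay, which is a limit and not a number. Compound 2 also stands at a limit, so no new step can be read from compound 2 to compound 4: the limit of > 3000 nM in this assay, at which 4 of the 4 values shown sit. The compounds shown leave open whether the methoxy to acetoxy change, or the difference between the cores of compound 1 and compound 2, alters inhibition in this assay at all.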